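Swapping a benzimidazole for a pyridine on the shared core

This account rests on a few compounds, and the source may have more. Where it says the series, first, only, none or still open, it means among the compounds named here.

Compound 1 `CCN(c1ccc(C#N)c(Cl)c1)c1cc(-n2cnc3ccccc32)ccc1C` has, in an ADME assay on L02 cells (Homo sapiens) for antiproliferative activity, read by CCK-8 assay, with a stated time of 6 days (a lower number here means a stronger inhibitor, a higher number a weaker inhibitor), the entry "not determined" (no result reported). Compound 3 `CCN(c1cccc(-n2ccnc2)c1)c1ccc(C#N)c(C(F)(F)F)c1` likewise has, in this assay, the entry "not determined" (no result reported), so compound 1 cannot be placed on a number of its own. The one figure available comes from compound 2 `N#Cc1ccc(N2CCCc3c(-c4ccncc4)cccc32)cc1C(F)(F)F`, which in this assay gives 6380 nM. Compound 4 `CCN(c1ccc(C#N)c(Cl)c1)c1cc(-c2cccnc2)ccc1C` differs from compound 1 by a single change on its core: pyridin-3-yl in place of 1H-benzimidazol-1-yl on an aromatic carbon. For the measured compounds named here, because no measured pair shows this change, its effect in this assay cannot be read from the data; the expectation is a step no larger than the usual scatter, in no clear direction. Taking compound 2 as the only anchor, compound 4 is estimated at 8000 nM, within a range from 2500 nM to 30000 nM.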

Compound 4, half-maximal inhibitory concentration: 12700 nM
Beside the measured number, compound 4's estimate is 1.6-fold (0.20 log units) below it; measured number inside the range.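

No new step can be read from compound 4, as it forms no readable pair with compound 1 in this assay. As far as these compounds go, whether pyridin-3-yl in place of 1H-benzimidazol-1-yl shifts activity stays open. Nothing shown explains the value of compound 4.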